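The source may report more compounds than this note shows. Statements on the series, on what has been measured and on what is new or still open speak of the compounds shown alone.

Measured in a functional assay on the whole organism (artery, strain albino) with Rattus norvegicus as the target, with a stated time of 900 min, at a dose of 10 mg/kg by the oral route; on this read-out higher numbers stand for more inhibition at the one dose given (going by the name of the read-out) and lower numbers for less inhibition:

compound 1 `CC1=C(C(=O)Nc2ccc(Br)cc2)C(c2ccc(Cl)cc2Cl)N=C(SCc2ccccc2)N1` gives 8.2%
compound 2 `CC1=C(C(=O)Nc2ccc(Br)cc2)C(c2ccc(Cl)cc2Cl)N=C(SCc2ccccc2Cl)N1` gives 16.4%
compound 3 `CC1=C(C(=O)Nc2ccc([N+](=O)[O-])cc2)C(c2ccc(Br)cc2)N=C(SCc2ccccc2)N1` gives 19.5%

Compounds 1 and 2 share a core and differ in one place: chloro in place of hydrogen on an aromatic carbon. The step this change made is a number 8.2 percentage points higher from compound 1 to compound 2 (within the scatter), so the two values cannot be told apart on this read-out. Compound 3 carries the highest of the three numbers, but its gap to compound 2 is within the scatter; only its gap to compound 1 is beyond it, so no order among the three is firm. The difference between the core of compound 3 and the core of compound 1 is not broken down here.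

Compound 4 `CC1=C(C(=O)Nc2ccc([N+](=O)[O-])cc2)C(c2ccc(Br)cc2)N=C(SCc2ccccc2Cl)N1` is the not yet measured partner of compound 3. It differs from compound 3 in one place: chloro in place of hydrogen on an aromatic carbon. The description of the place, and of the change, is the same word for word as that from compound 1 to compound 2, so this is the same change made on the other core.

With a single earlier instance, and that one within the scatter, the expectation rests on the pair compound 1 to compound 2 alone. In this assay the step expected from compound 3 to compound 4 is a number 5.5 percentage points higher from compound 3 to compound 4 (within the scatter), because a number 8.2 percentage points higher from compound 1 to compound 2 (within the scatter). Compound 4 is therefore expected at about 25%, with a range of 12% to 38%.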

Compound 4, a percentage reported as inhibition, in the whole organism at one dose (the size of the read-out at that dose, not a potency): 4.1%
Estimate against measurement, compound 4: 20.9 percentage points above, outside the stated range (below it).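

In this assay, the change from benzylsulfanyl to (2-chlorobenzyl)sulfanyl on the core of compound 3 gives a number 15.4 percentage points lower from compound 3 to compound 4 (beyond the scatter). The change therefore does not carry over as a fixed increment between these two cores, and its effect here depends on the core that bears it: the same change on two cores in this assay, a number 8.2 percentage points higher (within the scatter) from compound 1 to compound 2 and a number 15.4 percentage points lower (beyond the scatter) from compound 3 to compound 4, 23.6 percentage points apart, beyond the scatter of two such steps. This rests on one pair per core, the earlier step is itself within the scatter, and the data do not show which feature of the two cores lies behind the gap, nor how the change would behave on a third core.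

The compounds shown leave open what a fluoro or a methoxy group would do in the place of this chloro group, and what a longer chain or an amine would do in the place of the benzyl group on the sulfur. Also open, going by these compounds, is how the same change reads on cores that mix the features of compound 1 and compound 3, which would be needed to trace the gap to a single place.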